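A few compounds are considered here, and "the series" means these few. Any claim that something is new, unique, unknown or untested is made for them only; others in the source may bear on it.

Series notes, values from a physicochemical assay for lipophilicity, using the shake flask method; a higher number here means a more lipophilic compound, a lower number a more polar compound:

- compound 1 `C[C@H](Oc1ccc2ncc(CCC(=O)O)c(C3CC3)c2c1)c1c(Cl)ccc(F)c1Cl`: 4.1
- compound 2 `C[C@H](Oc1ccc2nc(OCCN)c(CCC(=O)O)c(C3CC3)c2c1)c1c(Cl)ccc(F)c1Cl`: 3.8
- compound 3 `C[C@H](Oc1cc(CO)c2ncc(/C=C/C(=O)O)c(C3CC3)c2c1)c1c(Cl)ccc(F)c1Cl`: 2.9

Compound 1 and compound 2 lie within the scatter of each other, and compound 3 gives a lower number than either. The next compound to be measured is compound 4 `C[C@H](Oc1ccc2ncc(S(=O)(=O)CC(=O)O)c(C3CC3)c2c1)c1c(Cl)ccc(F)c1Cl`. Going from compound 1 to compound 4 is a single change: (carboxymethyl)sulfonyl in place of 2-carboxyethyl on an aromatic carbon. In words, (carboxymethyl)sulfonyl stands in place of 2-carboxyethyl on an aromatic carbon, ortho to a cyclopropyl group.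

Within the data shown here, only one measured step is available, a number 0.30 log units lower from compound 1 to compound 2 (within the scatter). It puts 2-aminoethoxy in place of hydrogen, so it leaves the 2-carboxyethyl group untouched and says little about this change. Compound 3 differs from compound 1 in more than one place, so its number isolates no single change. The expectation therefore rests mainly on the structural change, with the hydrogen-bond acceptors going up and the donors staying level. Compound 3 at 2.9 shows how far down this series has reached so far, and the estimate is set near that number. The expected step is a number 1.10 log units lower from compound 1 to compound 4 (beyond the scatter), beyond the scatter. For compound 4 the estimated value in this assay is 3, with an expected range of 2.3 to 3.7.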

Compound 4, distribution coefficient: 2.5
Compound 4: middle estimate off by 0.50 log units, on the high side, within the range that was stated.
By their numbers in this assay, from the lowest: compound 4; then compound 3; then compounds 2 and 1 (each within the scatter of the next).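

In this assay, the aromatic carbon ortho to a cyclopropyl group and two atoms from the ring nitrogen responds strongly to a change in its side chain: putting (carboxymethyl)sulfonyl in place of 2-carboxyethyl gives a number 1.60 log units lower from compound 1 to compound 4 (beyond the scatter). Among these compounds, the only earlier single change, a number 0.30 log units lower from compound 1 to compound 2 (within the scatter), left the 2-carboxyethyl group untouched and stayed within the scatter, so this is the first step that can be read beyond the scatter and the first that alters this side chain. The count of hydrogen-bond acceptors rises while that of donors stays level, but no measurement shown gives a reason for the size of this step.

Going by these compounds, it remains open whether the step belongs to the sulfonyl unit itself or to the rest of the altered chain; a methylsulfonyl group without the carboxylic acid, or a longer chain on the sulfonyl, at this position would bear on that. Also open, on these data alone, is whether the same change gives a step of similar size on a core carrying the 2-aminoethoxy group of compound 2.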